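The source may report more compounds than this note shows. Statements on the series, on what has been measured and on what is new or still open speak of the compounds shown alone.

Compound 1 `CCC(C)n1ncn(-c2ccc(N3CCN(c4ccc(OC[C@@H]5CO[C@@](CBr)(c6ccc(Cl)cc6Cl)O5)cc4)CC3)cc2)c1=O`, compound 2 `CCC(C)n1ncn(-c2ccc(N3CCN(c4ccc(OC[C@@H]5CO[C@@](Cc6ccccc6)(c6ccc(Cl)cc6Cl)O5)cc4)CC3)cc2)c1=O` and compound 3 `CCC(C)n1ncn(-c2ccc(N3CCN(c4ccc(OC[C@@H]5CO[C@@](Cn6cnc(C)n6)(c6ccc(Cl)cc6Cl)O5)cc4)CC3)cc2)c1=O` share one core and differ only in the group on a saturated chain carbon bound to a saturated ring carbon. In a functional assay on HUVEC cells (Homo sapiens), read by scintillation counting and thymidine incorporation, with a stated time of 24 h (on this read-out higher numbers stand for weaker inhibition and lower numbers for stronger inhibition), compound 1, with bromo, gives 569 nM, and compound 2, with phenyl, gives 513 nM. Compound 3, with 3-methyl-1H-1,2,4-triazol-1-yl, gives 272 nM. That places compound 3 within the scatter of compound 2, as a 1.9-fold lower number from compound 2 to compound 3 (0.28 log units; within the scatter) shows, and only modestly clear of compound 1, as a 2.1-fold lower number from compound 1 to compound 3 (0.32 log units; beyond the scatter) shows.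

Compound 4 `CCC(C)n1ncn(-c2ccc(N3CCN(c4ccc(OC[C@@H]5CO[C@@](Cn6ccnc6C)(c6ccc(Cl)cc6Cl)O5)cc4)CC3)cc2)c1=O` carries 2-methyl-1H-imidazol-1-yl in that place instead: 2-methyl-1H-imidazol-1-yl in place of 3-methyl-1H-1,2,4-triazol-1-yl on a saturated chain carbon bound to a saturated ring carbon. Going by the values given here, no measured step exchanges one such ring for another. Among the compounds with values here, the only guidance comes from the much larger exchanges at this place, which moved this assay little: a 1.1-fold lower number from compound 1 to compound 2 (0.04 log units; within the scatter) and the steps to compound 3 above. A similar or smaller move is therefore expected, with no shift in either direction beyond the scatter. The expected step is a 1.1-fold higher number from compound 3 to compound 4 (0.03 log units; within the scatter). For compound 4 the estimated value is 290 nM, with an expected range of 130 nM to 620 nM.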

Compound 4, half-maximal inhibitory concentration: 173 nM
Compound 4: middle estimate off by 1.7-fold (0.22 log units), on the high side, and the stated range covers the measured number.
By their numbers in this assay, from the lowest: compounds 4, 3, 2 and 1 (each within the scatter of the next, the first and the last beyond it).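

Swapping one five-membered aromatic ring for another on a saturated chain carbon bound to a saturated ring carbon, with 2-methyl-1H-imidazol-1-yl replacing 3-methyl-1H-1,2,4-triazol-1-yl, stays within the scatter in this assay (a 1.6-fold lower number from compound 3 to compound 4 (0.20 log units; within the scatter)). Even so, 2-methyl-1H-imidazol-1-yl is the first group shown here to stand clear of both phenyl (a 3.0-fold lower number from compound 2 to compound 4 (0.47 log units; beyond the scatter)) and bromo (a 3.3-fold lower number from compound 1 to compound 4 (0.52 log units; beyond the scatter)), though both steps are modest, whereas compound 3 stood clear only of bromo. The data offer no explanation for this small separation.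

The compounds shown leave open whether the ring methyl contributes, since each ring here carries one. They also leave open how an open-chain amine such as dimethylamino or a carboxylic acid would behave at this place.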